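From nitro to fluoro at the limit of the assay

The source may report more compounds than this note shows. Statements on the series, on what has been measured and on what is new or still open speak of the compounds shown alone.

Compound 1 `CC(C)(O)c1cn(CC(=O)NCc2ccccc2)nn1` gives 1600 uM
Compound 2 `O=C(O)CCCCc1cn(CC(=O)NCc2ccccc2)nn1` gives 1080 uM
Compound 3 `O=C(Cn1cc(-c2cccc([N+](=O)[O-])c2)nn1)NCc1ccccc1` gives > 2000 uM as a limit

Within the data shown here, all three values come from an ADME assay on cells (spleen, Mus musculus, strain C57BL/6) for inhibition, read by flow cytometry and propidium iodide staining, with a stated time of 24 h, at 37 degrees C (on this read-out lower numbers stand for an effect already at smaller amounts and higher numbers for an effect only at larger amounts of compound), and only two of them are numbers. Compound 3 has no number and sits at the limit of > 2000 uM in this assay, at which 1 of the 3 values shown sits, so any step away from it can be sized only loosely.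

Compound 4 `O=C(Cn1cc(-c2cccc(F)c2)nn1)NCc1ccccc1` is still to be measured. It differs from compound 3 by a single swap, fluoro in place of nitro on an aromatic carbon and nothing else changes.

Among the measured compounds shown here, only one measured step bears on this swap, and only loosely. It is a 1.5-fold lower number from compound 1 to compound 2 (0.17 log units; within the scatter) and it also exchanges one group on an aromatic carbon, though neither nitro nor fluoro takes part in it. For the measured compounds named here, with that step from compound 1 to compound 2 as the only guide, no step beyond the scatter is expected in this assay and no firm direction can be claimed. The expected change is an at least 1.3-fold lower number from compound 3 to compound 4 (0.12 log units; that floor lies within the scatter) and this estimate stays within the scatter. Compound 4 is estimated at 1500 uM with a range of 700 uM to 3000 uM expected around it.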

Compound 4, concentration for half-maximal effect: "non-toxic" (no number reported)
The entry for compound 4 holds no number; no gap can be computed for the estimate.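

In this assay, among these compounds, compound 4 is reported as "non-toxic" (no number reported), without a number, so no step between compound 3 and compound 4 can be read. For compound 3 the entry > 2000 uM is a limit. The compounds shown leave open whether fluoro in place of nitro on an aromatic carbon changes this read-out at all, and in which direction.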